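Swapping 4-methoxyphenyl for 3,4-dichlorophenyl

The source may report more compounds than this note shows. Statements on the series, on what has been measured and on what is new or still open speak of the compounds shown alone.

Measured in a functional assay on Jurkat cells (Homo sapiens) for antiproliferative activity, read by MTT assay, with a stated time of 72 h; on this read-out lower numbers stand for stronger inhibition and higher numbers for weaker inhibition:
- compound 1 `COc1cc(-c2ncnn2-c2ccc(N)cc2)cc(OC)c1OC`: > 10000 nM, a limit
- compound 2 `COc1ccc(-n2ncnc2-c2cc(OC)c(OC)c(OC)c2)cc1`: 93 nM

Among the measured compounds shown here, compound 2 holds the only actual number. Compound 3 `COc1cc(-c2ncnn2-c2ccc(Cl)c(Cl)c2)cc(OC)c1OC` has 3,4-dichlorophenyl in place of 4-methoxyphenyl on an aromatic nitrogen. For the measured compounds named here, one measured step bears on this change, an at least 100-fold lower number from compound 1 to compound 2 (2.03 log units; beyond the scatter), where methoxy replaces amino on the same aryl group. That step is large, so a substantial shift is possible here too. With the methoxy gone, weaker inhibition is expected in this assay. The expected step is moderate, an 8.6-fold higher number from compound 2 to compound 3 (0.93 log units; beyond the scatter). Compound 3 is estimated at 800 nM, with an expected range of 150 nM to 5000 nM.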

Compound 3, half-maximal inhibitory concentration: > 10000 nM
Compound 3 gave a limit, no number; the forecaster's own chance of this, stated with the estimate: 15%; middle value at least 12-fold (1.09 log units) away from the limit.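

In this assay, 3,4-dichlorophenyl on the aromatic nitrogen gives an at least 100-fold higher number from compound 2 to compound 3 (2.03 log units; beyond the scatter), so the loss of activity seen with the amino compound is not confined to that group. Compound 1 and compound 3 both end at a limit, and the step between them cannot be read. Of the three groups at this position, only 4-methoxyphenyl gives an actual number, and the other two share the same limit: the limit of > 10000 nM in this assay, at which 2 of the 3 values shown sit.

Still open, going by these compounds, is how narrowly that number depends on methoxy. A 4-hydroxyphenyl or 4-ethoxyphenyl group on this nitrogen would test this directly.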